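Swapping bromo for methoxy on a benzotriazole modulator

A few compounds are considered here, and "the series" means these few. Any claim that something is new, unique, unknown or untested is made for them only; others in the source may bear on it.

Three close relatives share one core and have been tested in a functional assay on cells for positive allosteric modulation of metabotropic glutamate receptor 2 (Homo sapiens), read by fluorescence and calcium flux, with a stated time of 30 min; on this read-out higher numbers stand for an effect only at larger amounts of compound and lower numbers for an effect already at smaller amounts. Compound 1 `Brc1cccc2c1nnn2CC1CC1` gives 70 nM. Compound 2 `CCCCn1nnc2c(Br)cccc21` gives 60 nM, and compound 3 `Clc1cc(Br)c2nnn(CC3CC3)c2c1` gives 60 nM. Of the three numbers, that of compound 1 stands highest, yet the step of a 1.2-fold lower number from compound 1 to compound 2 (0.07 log units; within the scatter) and the step of a 1.2-fold lower number from compound 1 to compound 3 (0.07 log units; within the scatter) are both within the scatter, so the three cannot be told apart.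

Compound 4 `COc1cccc2c1nnn2CC1CC1` differs from compound 1 in one place: methoxy in place of bromo on an aromatic carbon. Neither measured step touches this position or this kind of exchange; one varies the chain on the triazole nitrogen, the other adds chloro elsewhere on the ring, and both left the number essentially unchanged. There is therefore no direct guide, and the halogen-to-ether swap is a larger change in character than either measured one, so a modest rise in the number is the cautious expectation, with wide uncertainty. Compound 4 is estimated at 200 nM, expected to fall between 60 nM and 700 nM. The expected step is a 2.9-fold higher number from compound 1 to compound 4 (0.46 log units; beyond the scatter).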

Compound 4, half-maximal effective concentration: 400 nM
Compound 4: the middle estimate sits 2.0-fold (0.30 log units) below what was measured; the measured number falls inside the stated range.
By their numbers in this assay, from the lowest: compounds 2, 3 and 1 (each within the scatter of the next); then compound 4.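

Unlike the two earlier exchanges, which altered the chain on the triazole nitrogen or added chloro elsewhere and stayed within the scatter, this exchange on the aromatic carbon carrying bromo clearly shifts the number in this assay (a 5.7-fold higher number from compound 1 to compound 4 (0.76 log units; beyond the scatter)). This carbon is therefore a place where the group matters: in this pair, methoxy needs a larger amount of compound than bromo for the same half-maximal effect. Nothing shown explains the difference.

A single exchange cannot show whether bromo is specifically favoured, or whether chloro, methyl, an amine or a nitrile on this carbon would stay close to compound 1 (70 nM). From the compounds shown here alone, it also remains open whether methoxy would have the same effect alongside the chain of compound 2 or the added chloro of compound 3.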